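Sulfonyl aryl swap in a 5-hydroxytryptamine receptor 4 ligand series

A few compounds are considered here, and "the series" means these few. Any claim that something is new, unique, unknown or untested is made for them only; others in the source may bear on it.

Measured so far:
- compound 1, `COc1cc(N)c(Cl)cc1C(=O)CCC1CCN(CCNS(=O)(=O)c2ccc(C)cc2)CC1`: 18 nM
- compound 2, `COc1ccc(S(=O)(=O)NCCCN2CCC(CCC(=O)c3cc(Cl)c(N)cc3OC)CC2)cc1`: 26 nM
- compound 3, `COc1ccc(S(=O)(=O)NCCN2CCC(CCC(=O)c3cc(Cl)c(N)cc3OC)CC2)cc1`: 12.3 nM

In an assay on brain for displacement of a labelled ligand from 5-hydroxytryptamine receptor 4 (Cavia porcellus), with a stated time of 30 min, in the presence of a further agent that is not named here (a lower number here means a stronger inhibitor, a higher number a weaker inhibitor), compound 1 stands second highest of the three numbers, though its gaps to compound 2 and to compound 3 are each within the scatter. Compound 4, `COc1cc(N)c(Cl)cc1C(=O)CCC1CCN(CCNS(=O)(=O)c2ccc(N)c(Br)c2)CC1`, differs from compound 1 in one place: 4-amino-3-bromophenyl in place of 4-methylphenyl on a sulfonyl sulfur. For the measured compounds named here, the only measured step on the same sulfonyl aryl group is a 1.5-fold lower number from compound 1 to compound 3 (0.17 log units; within the scatter), which shows that changing the group on that ring left the number essentially where it was. Going by the values given here, no measured step covers a bromine or an amino group on this ring, so the expectation rests on that single comparison. For compound 4 the expected step is a 1.1-fold higher number from compound 1 to compound 4 (0.05 log units; within the scatter), that is, no change beyond the scatter. Compound 4 is therefore estimated at 20 nM, between 7 nM and 55 nM.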

Compound 4, inhibition constant: 5.3 nM
Beside the measured number, compound 4's estimate is 3.8-fold (0.58 log units) above it, outside the stated range (below it).
By their numbers in this assay, from the lowest: compound 4; then compounds 3, 1 and 2 (each within the scatter of the next, the first and the last beyond it).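

In this assay the group on the sulfonyl sulfur can move the number beyond the scatter: 4-amino-3-bromophenyl gives a 3.4-fold lower number from compound 1 to compound 4 (0.53 log units; beyond the scatter) and also a 2.3-fold lower number from compound 3 to compound 4 (0.37 log units; beyond the scatter) in place of 4-methoxyphenyl. For the compounds shown here, the earlier methoxy for methyl change on this ring stayed within the scatter, so this is the first modest step at this position. Nothing available explains the step.

Going by these compounds, the amino group and the bromine entered together, so their separate shares stay open. A 4-aminophenyl or a 3-bromophenyl group on the sulfonyl sulfur would separate them.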